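A few compounds are considered here, and "the series" means these few. Any claim that something is new, unique, unknown or untested is made for them only; others in the source may bear on it.

In a functional assay on MCF7 cells (Homo sapiens), read by MTT assay, with a stated time of 48 h (on this read-out higher numbers stand for weaker inhibition and lower numbers for stronger inhibition), three compounds sharing one core have been measured. Compound 1 `CCN(CC)CCNC(=O)c1ccc(C(CC)(CC)c2ccc(OCC(=O)C(C)(C)C)c(C)c2)n1CC` gives 690 nM, compound 2 `CCn1c(C(=O)NCCCN(C)C)ccc1C(CC)(CC)c1ccc(OCC(=O)C(C)(C)C)c(C)c1` gives 340 nM and compound 3 `CCN(CC)CCCNC(=O)c1ccc(C(CC)(CC)c2ccc(OCC(=O)C(C)(C)C)c(C)c2)n1CC` gives 530 nM. Compound 2 sits at the low end of these numbers: its nearest neighbour is marked by a 1.6-fold higher number from compound 2 to compound 3 (0.19 log units; within the scatter), its furthest by a 2.0-fold lower number from compound 1 to compound 2 (0.31 log units; beyond the scatter).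

Compound 4 `CCn1c(C(=O)NCCN)ccc1C(CC)(CC)c1ccc(OCC(=O)C(C)(C)C)c(C)c1` differs from compound 2 by a single change, (amino in place of (dimethylamino)methyl on a saturated chain carbon, two bonds along the chain from an amide-type nitrogen), with amino in place of (dimethylamino)methyl on a saturated chain carbon, two bonds along the chain from an amide-type nitrogen. Going by the values given here, two measured steps touch this same place: a 2.0-fold lower number from compound 1 to compound 2 (0.31 log units; beyond the scatter) and a 1.3-fold lower number from compound 1 to compound 3 (0.11 log units; within the scatter). Among the compounds with values here, both are small, but no measured compound carries amino there, so they guide the size of the step better than its direction. Compound 1 also lacks (dimethylamino)methyl at this place and gives 690 nM, which points weakly upward. The expected change in this assay is a 1.6-fold higher number from compound 2 to compound 4 (0.21 log units; within the scatter). For compound 4 the estimated value is 550 nM, with an expected range of 220 nM to 1400 nM.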

Compound 4, half-maximal inhibitory concentration: 75 nM
For compound 4 the middle estimate is 7.3-fold (0.87 log units) above the measured one; the whole stated range lies above it.
By their numbers in this assay, from the lowest: compound 4; then compounds 2, 3 and 1 (each within the scatter of the next, the first and the last beyond it).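

In this assay, swapping one substituted amine for another at this chain end had moved the number only slightly, whereas the unsubstituted amino group of compound 4 brings a clear change: a 4.5-fold lower number from compound 2 to compound 4 (0.66 log units; beyond the scatter), a 7.1-fold lower number from compound 3 to compound 4 (0.85 log units; beyond the scatter) and a 9.2-fold lower number from compound 1 to compound 4 (0.96 log units; beyond the scatter). The last of these steps is the cleanest to read, since amino simply takes the place of diethylamino at the same spot on the chain, while the other two also swap a 3-(dimethylamino)propyl or longer chain for the 2-aminoethyl chain; with all three steps beyond the scatter, compound 4 is the strongest inhibitor of the four. No measurement shown gives a reason for this drop.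

As far as these compounds go, what remains open is how much depends on the bare amino group and how much on chain length. A 3-aminopropyl chain, or a methylamino group on the 2-aminoethyl chain's place, would help separate the two.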